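Amide variations on a shared benzothiazolyl-anilide core

The source may report more compounds than this note shows. Statements on the series, on what has been measured and on what is new or still open speak of the compounds shown alone.

Three compounds share one core and have been measured in an ADME assay on BJ cells (Homo sapiens) for inhibition, with a stated time of 72 h; on this read-out higher numbers stand for an effect only at larger amounts of compound and lower numbers for an effect already at smaller amounts:

Compound 1 `C=C(C)C(=O)Nc1cccc(-c2nc3ccccc3s2)c1` gives > 25000 nM, which is a limit of the assay.
Compound 2 `O=C(CCl)Nc1cccc(-c2nc3ccccc3s2)c1` gives 8500 nM.
Compound 3 `CC(C)(CCl)C(=O)Nc1cccc(-c2nc3ccccc3s2)c1` gives > 25000 nM, again a limit of the assay.

Compound 3 therefore stands at the limit, as does compound 1 (the limit of > 25000 nM in this assay, at which 2 of the 3 values shown sit); only compound 2 gives a number. The step of an at least 2.9-fold higher number from compound 2 to compound 3 (0.46 log units; beyond the scatter) is the only readable one that reaches compound 3, while a step that the two limits leave unreadable from compound 1 to compound 3 cannot be sized.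

Compound 4 `O=C(Nc1cccc(-c2nc3ccccc3s2)c1)c1cccnc1Cl` differs from compound 3 by 2-chloropyridin-3-yl in place of 1-(chloromethyl)-1-methylethyl on a carbonyl carbon. Going by the values given here, no measured step replaces an alkyl group by an aromatic ring at this position, so the nearest guidance is that compound 3 itself sits at the limit. Compound 4 is expected to remain at or near that limit, with the step that the limit leaves unreadable from compound 3 to compound 4 estimated to lie within the scatter. The estimate for compound 4 in this assay is 30000 nM, with a range from 8000 nM to 100000 nM.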

Compound 4, half-maximal effective concentration: > 25000 nM
Compound 4 was reported as a limit (the forecaster's own chance of this, stated with the estimate: 70%); the middle value does not contradict the limit.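

In this assay, going by these compounds alone, compound 4 stands at a limit of the assay, which shows that an aromatic ring on this carbonyl carbon, absent from the earlier compounds, also gives no number here: the limit of > 25000 nM in this assay, at which 3 of the 4 values shown sit. A step of an at least 2.9-fold higher number from compound 2 to compound 4 (0.46 log units; beyond the scatter) is the only new step that can be read, so among the groups shown on this carbon, chloromethyl remains the only one that gives a number, now compared with 2-chloropyridin-3-yl as well as with 1-methylethenyl and 1-(chloromethyl)-1-methylethyl. The steps from compound 3 and from compound 1 to compound 4 cannot be read, since both ends of each are limits.

As far as these compounds go, how far compound 1, compound 3 and compound 4 lie from one another stays open. Also open, from the compounds shown here alone, is what a bromomethyl group or a longer chloroalkyl chain would give on this carbonyl carbon.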